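The source may hold more compounds than are shown below. What is called first, only, known or untested is meant among the compounds shown, and "the series" means these compounds.

Measured compounds in the series:

compound 1 `CC1(C)[C@H]2CC[C@]1(C)N(Cc1cn(-c3cccc(F)c3)nn1)C(=O)C2` — 530 nM
compound 2 `CC1(C)[C@H]2CC[C@]1(C)N(Cc1cn(-c3ccc(F)cc3)nn1)C(=O)C2` — 500 nM
compound 3 `Cc1ccc(-n2cc(CN3C(=O)C[C@@H]4CC[C@@]3(C)C4(C)C)nn2)cc1` — 390 nM

All three share one core and differ only in the aryl group on the aromatic nitrogen of the triazole. In a functional assay on SGC-7901 cells (Homo sapiens) for inhibition, read by MTT assay, with a stated time of 24 h (on this read-out lower numbers stand for stronger inhibition and higher numbers for weaker inhibition), compound 1 gives the highest of the three numbers, but the gap to its neighbours is small: a 1.1-fold lower number from compound 1 to compound 2 (0.03 log units; within the scatter) and a 1.4-fold lower number from compound 1 to compound 3 (0.13 log units; within the scatter), and also a 1.3-fold lower number from compound 2 to compound 3 (0.11 log units; within the scatter). None of these steps leaves the scatter, so on the numbers in hand the three aryl variants cannot be told apart.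

The next compound, compound 4 `Cc1ccccc1-n1cc(CN2C(=O)C[C@@H]3CC[C@@]2(C)C3(C)C)nn1`, is again a variation at the same place. Relative to compound 1 the change is 2-methylphenyl in place of 3-fluorophenyl on an aromatic nitrogen. The three measured steps all bear on it, since each exchanges one substituted phenyl for another on that nitrogen, and each stayed within the scatter. There is thus no measured basis for expecting a step beyond the scatter in this assay in either direction; the working assumption is that compound 4 lands in the same band as compounds 1, 2 and 3.

Compound 4 is therefore expected to give 470 nM (range 220 nM to 1000 nM), which means an expected step of a 1.1-fold lower number from compound 1 to compound 4 (0.05 log units; within the scatter).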

Compound 4, half-maximal inhibitory concentration: 350 nM
The estimate for compound 4 lay 1.3-fold (0.13 log units) above the measured number; the measured number falls inside the stated range.
By their numbers in this assay, from the lowest: compounds 4, 3, 2 and 1 (each within the scatter of the next).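

With 2-methylphenyl, the substituted phenyl on the aromatic nitrogen now carries its group at a third ring position, and in this assay this still gives no readable separation from 3-fluorophenyl (a 1.5-fold lower number from compound 1 to compound 4 (0.18 log units; within the scatter)) or from 4-fluorophenyl (a 1.4-fold lower number from compound 2 to compound 4 (0.15 log units; within the scatter)). The pair of compound 3 and compound 4 adds the first comparison of one substituent at two ring positions, and exchanging 4-methylphenyl for 2-methylphenyl also stays inside the scatter (a 1.1-fold lower number from compound 3 to compound 4 (0.05 log units; within the scatter)), so among these four compounds neither the choice between methyl and fluoro nor the placement of the group on the phenyl can be read as changing the result. No measurement in hand offers an explanation for this flat behaviour at the position.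

Going by these compounds, whether this tolerance extends beyond small substituents on a phenyl remains open, as all four compounds keep that ring: a carboxylic acid or a dimethylamino group on the phenyl, or a longer alkyl chain in place of the aryl, could still give a step beyond the scatter. Also open, on these data alone, is whether changes to the shared core or to the methylene link to the triazole would move the number in this assay when the aryl group has so little measurable influence.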